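The source may report more compounds than this note shows. Statements on the series, on what has been measured and on what is new or still open speak of the compounds shown alone.

Measured so far in a functional assay on TREX cells for negative allosteric modulation of metabotropic glutamate receptor 3 (Rattus norvegicus), read by calcium flux, with a stated time of 2.5 min; a higher number here means a weaker inhibitor, a lower number a stronger inhibitor:
Compound 1, `COc1ccc(C#Cc2ccc(C(=O)N3CCC[C@@H](CO)C3)cc2)c(F)c1`, gives > 10000 nM, which is a limit of the assay and not a number.
Compound 2, `CCOc1ccc(C#Cc2ccc(C(=O)N3CCC[C@@H](CO)C3)cc2)cc1`, gives > 10000 nM, again only a limit.
Compound 3, `O=C(c1ccc(C#Cc2ccc(O)cc2)cc1)N1CCC[C@@H](CO)C1`, gives > 10000 nM, again only a limit.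

Compound 3 therefore stands at the ceiling of what this assay reports, and it does not stand there alone (the limit of > 10000 nM in this assay, at which 3 of the 3 values shown sit). Compound 4, `COc1ccc(C#Cc2ccc(C(=O)N3CCC[C@@H](CO)C3)cc2)cc1F`, differs from compound 3 in one place: 3-fluoro-4-methoxyphenyl in place of 4-hydroxyphenyl on a triple-bonded carbon. The measured steps that touch this kind of change are the swaps of the group on the triple-bonded carbon: a step that the two limits leave unreadable from compound 1 to compound 3, a step that the two limits leave unreadable from compound 2 to compound 3 and a step that the two limits leave unreadable from compound 1 to compound 2. None of them has a readable size, since each begins and ends at the limit. Compound 1 carries a 2-fluoro-4-methoxyphenyl group on the triple-bonded carbon, close in kind to the 3-fluoro-4-methoxyphenyl group that enters in compound 4. Compound 1 sits at the limit. No step beyond the scatter is therefore expected in this assay; the expected step is a step that the limit leaves unreadable from compound 3 to compound 4. For compound 4 the estimate is 15000 nM, within 5000 nM to 50000 nM, and most likely reported again only as a limit.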

Compound 4, half-maximal inhibitory concentration: > 10000 nM
Compound 4 was reported as a limit; the forecaster's own chance of this, stated with the estimate: 80%; the middle value lies beyond the limit too.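

Compound 4 gives > 10000 nM, which is a limit and not a number. Its steps from compound 1, compound 2 and compound 3 cannot be read, and all four compounds sit at the same limit: the limit of > 10000 nM in this assay, at which 4 of the 4 values shown sit.

The compounds shown leave open which group on the triple-bonded carbon, if any, would give a readable value in this assay.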